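Carbonyl-linked enone on the shared core: compound 3

The source may hold more compounds than are shown below. What is called first, only, known or untested is meant among the compounds shown, and "the series" means these compounds.

Compound 1 `COc1ccc(C(=O)/C=C/c2cc(-c3cc(OC)c(OC)c(OC)c3)n3nc(-c4ccccc4)cc3n2)cc1OC` and compound 2 `COc1cc(-c2cc(/C=C/C(=O)c3ccc(C)c(C)c3)nc3cc(-c4ccccc4)nn23)cc(OC)c1OC` share one core and differ only in the aryl on the carbonyl carbon. In an ADME assay on HEK293 cells (Homo sapiens) for antiproliferative activity, read by MTT assay, with a stated time of 24 h (on this read-out higher numbers stand for weaker inhibition and lower numbers for stronger inhibition), compound 1 gives 81700 nM, and compound 2 gives 72500 nM. Among the measured compounds shown here, the single measured step, a 1.1-fold lower number from compound 1 to compound 2 (0.05 log units; within the scatter), put 3,4-dimethylphenyl in place of 3,4-dimethoxyphenyl on a carbonyl carbon. On the two numbers shown, compound 2 stands at the low end, but its gap to compound 1 is within the scatter, so the two are not separated.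

Compound 3 `COc1cc(-c2cc(C(=O)/C=C/c3ccc(C)cc3)nc3cc(-c4ccccc4)nn23)cc(OC)c1OC` differs from compound 2 by (2-(4-methylphenyl)ethenyl)carbonyl in place of 2-((3,4-dimethylphenyl)carbonyl)ethenyl on an aromatic carbon. The entering group is attached through its carbonyl, the leaving group through its ethenyl, and the aryl is 4-methylphenyl rather than 3,4-dimethylphenyl. For the measured compounds named here, no measured step covers such a change; the only step, a 1.1-fold lower number from compound 1 to compound 2 (0.05 log units; within the scatter), altered the aryl alone and stayed within the scatter. For the step to compound 3 a value of a 1.0-fold higher number from compound 2 to compound 3 (0.01 log units; within the scatter) is expected, meaning no movement beyond the scatter. Compound 3 is estimated at 75000 nM, within 30000 nM to 190000 nM.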

Compound 3, half-maximal inhibitory concentration: 56100 nM
For compound 3 the middle estimate is 1.3-fold (0.13 log units) above the measured one; measured number inside the range.
By their numbers in this assay, from the lowest: compounds 3, 2 and 1 (each within the scatter of the next).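

In this assay, reversing the attachment of the enone on the aromatic carbon next to the ring nitrogen, so that it is bound through its carbonyl rather than its ethenyl, and exchanging 3,4-dimethylphenyl for 4-methylphenyl gives a 1.3-fold lower number from compound 2 to compound 3 (0.11 log units; within the scatter). The earlier step altered only the aryl, whereas this one alters the linkage at the shared core as well, and even this larger change leaves the two compounds unseparated. No measured evidence bears on why the numbers stay this close, and with both changes made in one step, neither can be assessed alone.

On these data alone, it remains open whether the linkage reversal alone, with the aryl kept as 3,4-dimethylphenyl, leaves the number equally unmoved. As far as these compounds go, it is also open whether an amine or a carboxylic acid on this aromatic carbon, in place of the enone, would move the number beyond the scatter.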